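This account rests on a few compounds, and the source may have more. Where it says the series, first, only, none or still open, it means among the compounds named here.

Among the compounds measured in an assay on CHO-K1 cells for displacement of a labelled ligand from adenosine receptor A1 (Homo sapiens), read by scintillation counting, with a stated time of 60 min (a lower number here means a stronger inhibitor, a higher number a weaker inhibitor), compound 2 `CCCCc1nc(/C=N/Nc2nc(N)c3ncn([C@@H]4O[C@H](CO)[C@@H](O)[C@H]4O)c3n2)c(Cl)[nH]1` stands lowest with 12 nM. Compound 1 `CC(/C=N/Nc1nc(N)c2ncn([C@@H]3O[C@H](CO)[C@@H](O)[C@H]3O)c2n1)Cc1ccc(C(C)C)cc1` comes nearest, yet its value of 9500 nM lies far above that of compound 2, well beyond the scatter. For compound 3 `Nc1nc(N/N=C/c2ccc(N(c3ccccc3)c3ccccc3)cc2)nc2c1ncn2[C@@H]1O[C@H](CO)[C@@H](O)[C@H]1O` this assay gives only a limit, > 10000 nM, not a number; this is the limit of > 10000 nM in this assay, at which 1 of the 3 values shown sits. Compound 4 `CCCCC/C=C/C=C/C=N/Nc1nc(N)c2ncn([C@@H]3O[C@H](CO)[C@@H](O)[C@H]3O)c2n1` has not yet been measured. It differs from compound 2 in one place: a group of 9 heavy atoms (9 carbon; no ring) in place of a group of 10 heavy atoms (7 carbon, 2 nitrogen, 1 chlorine; one five-membered aromatic ring with 2 hetero atoms), on a carbon with a double bond to nitrogen. Because compound 1, whose substituent likewise carries no five-membered aromatic ring with hetero atoms, gives 9500 nM, the expected step of a 250-fold higher number from compound 2 to compound 4 (2.40 log units; beyond the scatter) is a large rise. Compound 4 is therefore estimated at 3000 nM, within a range from 500 nM to 15000 nM.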

Compound 4, inhibition constant: 2 nM
Compound 4: the middle estimate sits 1500-fold (3.18 log units) above what was measured, outside the stated range (below it).
By their numbers in this assay, from the lowest: compound 4; then compound 2; then compound 1. At a limit, above all of these: compound 3.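

In this assay, putting an open carbon chain with 2 double bonds in place of the 2-butyl-5-chloro-1H-imidazol-4-yl group gives a 6.0-fold lower number from compound 2 to compound 4 (0.78 log units; beyond the scatter). So at this position, on a carbon with a double bond to nitrogen, a low number needs neither the five-membered aromatic ring nor the chlorine, and a substituent with 0 hydrogen-bond donors or acceptors suffices. Nothing shown here explains why the chain gives the lower number. Still open is whether the double bonds matter, since a fully saturated chain is not among the compounds shown. A longer chain, or one ending in an amine, would test how much this position tolerates.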